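Series notes: amine head group swap on the shared core

The compounds below may be only part of what the source reports. "The series", "measured", "known", "first", "only" and "open" are said of these compounds alone.

Compound 1 `Oc1ccc(CNc2cc(C(F)(F)F)cc3[nH]ncc23)cc1` is, in an assay for inhibition of Indoleamine 2,3-dioxygenase 1 (Homo sapiens), with stated times of 10 min and 60 min, tested at 100 uM (on this read-out lower numbers stand for a weaker effect and higher numbers for a stronger effect at the one concentration tested), the lower of the two measured compounds, giving 81%. For the measured compounds named here, compound 2 `Oc1ccc(CNc2cc(C(F)(F)F)cc3[nH]ncc23)c(Cl)c1` gives 95% in this assay, and the only measured step, a number 14 percentage points higher from compound 1 to compound 2 (beyond the scatter), concerns chloro in place of hydrogen on an aromatic carbon and does not touch the head group. Compound 3 `FC(F)(F)c1cc(NC[C@H]2CCCCN2)c2cn[nH]c2c1` differs from compound 1 by piperidin-2-yl in place of 4-hydroxyphenyl on a saturated chain carbon bound to a nitrogen on an aromatic ring. Going by the values given here, no measured step bears on such a replacement, so nothing from the measured pairs fixes its direction or size, and the expectation rests on the single value of compound 1 alone. Given the absence of any related step, compound 3 is estimated to move by a number 26 percentage points lower from compound 1 to compound 3 (beyond the scatter), with wide uncertainty. The estimate for compound 3 in this assay is therefore 55%, expected between 15% and 90%.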

Compound 3, a percentage reported as inhibition, at one concentration (the size of the read-out at that concentration, not a potency): 69%
Compound 3: the middle estimate sits 14 percentage points below what was measured; the measured number falls inside the stated range.
By their numbers in this assay, from the lowest: compound 3; then compound 1; then compound 2.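

Replacing 4-hydroxyphenyl with piperidin-2-yl on the saturated chain carbon bound to a nitrogen on an aromatic ring gives, in this assay, a number 12 percentage points lower from compound 1 to compound 3 (beyond the scatter), so this is a modest loss and not a collapse of the read-out. This position therefore accepts a non-aromatic ring with a hetero atom as well as an aromatic ring of carbon only, with compound 3 still at 69% at the one concentration tested, which is not a measure of potency. No measurement at hand explains the step.

The change alters ring type, hetero atom and hydroxyl together, so a plain phenyl or a cyclohexyl group would be needed to separate these contributions. The effect of the defined stereocentre also stays open, as the opposite enantiomer of compound 3 is not among the compounds shown.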